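This account rests on a few compounds, and the source may have more. Where it says the series, first, only, none or still open, it means among the compounds named here.

Measured compounds:
Compound 1, `COc1ccc(Nc2ccc3cc(NC(=O)c4ccc(OC(C)=O)c(CC=C(C)C)c4)c(=O)oc3c2C)cc1`: > 100000 nM
Compound 2, `COc1ccc(Cc2ccc3cc(NC(=O)c4ccc(OC(C)=O)c(CC=C(C)C)c4)c(=O)oc3c2C)cc1`: 23500 nM
Compound 3, `COc1ccc(Cc2ccc3cc(NC(=O)c4ccc(O)c(CC=C(C)C)c4)c(=O)oc3c2C)cc1`: 11100 nM

Of the compounds shown here, three built on a shared core have been tested in a functional assay on SK-BR-3 cells (Homo sapiens) for antiproliferative activity; a higher number here means a weaker inhibitor, a lower number a stronger inhibitor. For compound 1 the result is only a limit of the assay, > 100000 nM, not a number (the limit of > 100000 nM in this assay, at which 1 of the 3 values shown sits). Compound 2 gives 23500 nM, and compound 3 gives 11100 nM. Among the two numbers shown, compound 2 stands highest; its nearest neighbour is compound 3, reached by a 2.1-fold lower number from compound 2 to compound 3 (0.33 log units; beyond the scatter). The other measured step, an at least 4.2-fold lower number from compound 1 to compound 2 (0.62 log units; beyond the scatter), is a limit-based comparison.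

Compound 4, `COCOc1ccc(Cc2ccc3cc(NC(=O)c4ccc(OC(C)=O)c(CC=C(C)C)c4)c(=O)oc3c2C)cc1OC`, has not yet been measured. It differs from compound 2 in one place: 3-methoxy-4-(methoxymethoxy)phenyl in place of 4-methoxyphenyl on a saturated chain carbon bound to an aromatic carbon. Neither measured step bears on this part of the molecule. The step from compound 1 to compound 2 changed the link to the aromatic ring, and the step from compound 2 to compound 3 changed the acetyl on the other side of the core; nothing shows how added substituents on the 4-methoxyphenyl ring itself affect potency. The expectation is therefore a step no larger than the scatter, in no particular direction. The step expected here is a 1.2-fold lower number from compound 2 to compound 4 (0.07 log units; within the scatter). Compound 4 is estimated to give about 20000 nM, within a range of 7000 nM to 60000 nM.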

Compound 4, half-maximal inhibitory concentration: 14200 nM
Compound 4: the middle estimate sits 1.4-fold (0.15 log units) above what was measured; low and high end bracket the measured number.
By their numbers in this assay, from the lowest: compounds 3, 4 and 2 (each within the scatter of the next, the first and the last beyond it). At a limit, above all of these: compound 1.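

In this assay, putting 3-methoxy-4-(methoxymethoxy)phenyl in place of 4-methoxyphenyl on a saturated chain carbon bound to an aromatic carbon gives a 1.7-fold lower number from compound 2 to compound 4 (0.22 log units; within the scatter), so compound 2 and compound 4 cannot be told apart. Among these compounds, this pair is the first to probe the ring itself rather than its link to the core or the acetyl on the other side, and it shows that a group of 12 heavy atoms with 3 hydrogen-bond acceptors, entering for one of 8 heavy atoms with 1 acceptor, leaves the result within the usual scatter of repeated measurements. Nothing available here explains why the number holds through this change.

The two new groups arrive together, so this single pair cannot show what the methoxy and the methoxymethoxy each contribute, or whether their contributions offset each other. It also leaves open how a free hydroxyl, an amine or a carboxylic acid on this ring would behave, and whether hydrogen in place of acetyl on the oxygen would have the same effect with this ring present.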